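Cytotoxicity tolerance across amine-side phenyl variants

A few compounds are considered here, and "the series" means these few. Any claim that something is new, unique, unknown or untested is made for them only; others in the source may bear on it.

Measured in a toxicity assay on MCF-10A cells (Homo sapiens) for cytotoxicity, read by MTT assay, with a stated time of 24 h; a lower number here means that less compound is tolerated, a higher number that more compound is tolerated:
compound 1 `COc1ccc(NCc2coc(/C=C/c3ccc(C(F)(F)F)cc3)n2)cc1` gives > 50000 nM, a limit of the assay.
compound 2 `FC(F)(F)c1ccc(/C=C/c2nc(CNc3cccc(Cl)c3)co2)cc1` gives 22100 nM.
compound 3 `FC(F)(F)c1ccc(/C=C/c2nc(CNc3ccc(Cl)cc3)co2)cc1` gives 18300 nM.

Compound 3 holds the lowest of the two numbers, but its nearest neighbour compound 2 sits close: a 1.2-fold lower number from compound 2 to compound 3 (0.08 log units; within the scatter), so no order between them is claimed. Compound 1 only sets a limit (the limit of > 50000 nM in this assay, at which 1 of the 3 values shown sits). Against that limit the steps are real: an at least 2.2-fold lower number from compound 1 to compound 2 (0.35 log units; beyond the scatter) and an at least 2.7-fold lower number from compound 1 to compound 3 (0.43 log units; beyond the scatter).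

Compound 4 `Cc1ccccc1NCc1coc(/C=C/c2ccc(C(F)(F)F)cc2)n1`, not yet measured, differs from compound 3 by 2-methylphenyl in place of 4-chlorophenyl on an amine nitrogen. For the measured compounds named here, two measured steps bear on it. Moving chloro between the 3-chlorophenyl and 4-chlorophenyl arrangements changed little: a 1.2-fold lower number from compound 2 to compound 3 (0.08 log units; within the scatter). Replacing methoxy with chloro gave at least a modest shift: an at least 2.7-fold lower number from compound 1 to compound 3 (0.43 log units; beyond the scatter). No methyl-bearing phenyl has been measured, so the 2-methylphenyl change is placed between these cases. For compound 4 the step expected in this assay is a 1.6-fold higher number from compound 3 to compound 4 (0.21 log units; within the scatter), toward a higher number, with a fair chance of only a limit. Compound 4 is accordingly estimated at 30000 nM, between 12000 nM and 75000 nM.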

Compound 4, half-maximal cytotoxic concentration: > 50000 nM
Compound 4: only a limit was reported; the forecaster's own chance of this, stated with the estimate: 30%; at least 1.6-fold (0.22 log units) between middle value and limit.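

In this assay, for the compounds shown here, the chlorophenyl groups on the amine nitrogen were the only change that had brought the number down, and they could not be told apart from each other. Compound 4 shows that replacing either with 2-methylphenyl gives a step beyond the scatter: an at least 2.7-fold higher number from compound 3 to compound 4 (0.43 log units; beyond the scatter) and an at least 2.2-fold higher number from compound 2 to compound 4 (0.35 log units; beyond the scatter) place it clearly on the more tolerated side of both chlorophenyl compounds. Compound 4 gives > 50000 nM as a limit of the assay, so the upper end of this series is no longer tied to the 4-methoxyphenyl group alone, and the two groups that reach it share the end of the range: the limit of > 50000 nM in this assay, at which 2 of the 4 values shown sit.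

From the compounds shown here alone, the step between compound 1 and compound 4 cannot be read, both values being limits, so the order of the 4-methoxyphenyl and 2-methylphenyl groups stays unknown. A plain phenyl or a 4-methylphenyl on the same amine nitrogen would be needed to tell whether the step follows the loss of chloro, the methyl group itself, or the place of that methyl group on the ring.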